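The source may hold more compounds than are shown below. What is called first, only, known or untested is meant among the compounds shown, and "the series" means these compounds.

Compound 1 `C#Cc1cccc(N/N=N/c2ccc(C(=N)N)cc2)c1` carries a bare ethynyl group, and in a functional assay on PC-3 cells (Homo sapiens) for antiproliferative activity, read by WST assay, with a stated time of 72 h (a higher number here means a weaker inhibitor of growth, a lower number a stronger inhibitor of growth), compound 1 gives 18000 nM. Among the compounds with values here, that is the higher of the two numbers known so far. Compound 2 `N=C(N)c1ccc(/N=N/Nc2ccccc2C#Cc2ccccc2)cc1` gives 5300 nM, a lower number by more than the usual scatter of such measurements, so compound 1 is the weaker growth inhibitor of the pair.

Compound 3 `N=C(N)c1ccc(/N=N/Nc2cccc(C#Cc3ccc(F)cc3)c2)cc1` keeps the core of compound 1 and differs in one place: 4-fluorophenyl in place of hydrogen on a triple-bonded carbon. A 4-fluorophenyl group takes the place of hydrogen on a triple-bonded carbon, so ethynyl becomes 2-(4-fluorophenyl)ethynyl.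

Within the data shown here, no measured pair shows this change directly. The closest guide is compound 2, whose triple bond also carries a six-membered aromatic ring of carbon only and which gives 5300 nM. Among the measured compounds shown here, this is thin evidence, and nothing measured so far contains fluorine. Even so, a downward step beyond the scatter is expected in this assay, a 3.3-fold lower number from compound 1 to compound 3 (0.51 log units; beyond the scatter), which would mean stronger inhibition of growth. The estimate for compound 3 is 5500 nM, with an expected range of 1800 nM to 16000 nM.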

Compound 3, concentration for 50% growth inhibition: 5300 nM
The estimate for compound 3 lay 1.0-fold (0.02 log units) above the measured number; the range from low to high includes it.
By their numbers in this assay, from the lowest: compounds 2 and 3 (each within the scatter of the next); then compound 1.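

Within the data shown here, compound 1 and compound 3 give the first direct comparison at this position, a triple-bonded carbon whose only other neighbour is the second triple-bonded carbon. In this assay the exchange of hydrogen for 4-fluorophenyl gives a 3.4-fold lower number from compound 1 to compound 3 (0.53 log units; beyond the scatter) and so shows that this carbon can carry a group of 7 heavy atoms with stronger, not weaker, inhibition of growth. The step is modest, and no measured property of these compounds accompanies it, so the data give no reason for the change.

This single pair cannot separate the contribution of the six-membered aromatic ring from that of the fluorine, so a plain phenyl group on the same carbon remains an open comparison. The compounds shown also leave open how this position would respond to quite different groups, such as a hydroxymethyl group, an amine, a carboxylic acid or a longer carbon chain, and whether any of them would move the number further in either direction.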